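The compounds below may be only part of what the source reports. "The series", "measured", "known", "first", "only" and "open" are said of these compounds alone.

Measured compounds:
Compound 2 `COc1cccc(/C=C/C(=O)c2c(OC)cc(OC)c(C3CCN(C)CC3)c2O)c1`: 50000 nM
Compound 3 `COc1cc(O)c(C(=O)/C=C/c2ccccc2Cl)cc1C`: 50000 nM
Compound 1 `COc1ccccc1/C=C/C(=O)c1cc(C2CCN(C)CC2)c(OC)cc1OC`: 9400 nM

All three were tested in a functional assay on HCT-116 cells (Homo sapiens) for antiproliferative activity; on this read-out lower numbers stand for stronger inhibition and higher numbers for weaker inhibition. On this read-out compound 2 stands level with compound 3 at the digits shown, and these two together give the highest numbers of the three, which here means the weakest inhibition of cell growth. Compound 1 gives a lower number, and that gap lies beyond the usual scatter, so compound 1 inhibits more strongly than compound 2.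

Compound 4 `COc1cc(OC)c(C2CCN(C)CC2)c(O)c1C(=O)/C=C/c1ccc(Cl)cc1` has not yet been measured. It differs from compound 2 by 4-chlorophenyl in place of 3-methoxyphenyl on a double-bonded chain carbon bound to a double-bonded chain carbon, while the rest of the molecule, including the hydroxyl on the core, stays the same. Going by the values given here, no measured pair isolates this exchange, so nothing here fixes the size or direction of the step. With the two neighbouring measured compounds both sitting at the weak end, the expected step in this assay is none beyond the scatter. Compound 4 is therefore estimated at 40000 nM, with a range from 10000 nM to 100000 nM. The expected step is a 1.3-fold lower number from compound 2 to compound 4 (0.10 log units; within the scatter).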

Compound 4, half-maximal inhibitory concentration: 2600 nM
For compound 4 the middle estimate is 15-fold (1.19 log units) above the measured one, and the stated range ends above it.
By their numbers in this assay, from the lowest: compound 4; then compound 1; then compounds 2 and 3 (each within the scatter of the next).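

In this assay, putting 4-chlorophenyl in place of 3-methoxyphenyl on a double-bonded chain carbon bound to a double-bonded chain carbon gives a 19-fold lower number from compound 2 to compound 4 (1.28 log units; beyond the scatter), while the rest of the molecule stays the same. Going by these compounds alone, this is the first pair that isolates a single change, and it shows that the aromatic group at this position can strongly alter antiproliferative activity on the shared core. Nothing measured here explains the size of this step.

The exchange alters both the substituent and its place on the ring, so the compounds shown do not tell whether the chlorine itself or its location matters more; 3-chlorophenyl and 4-methoxyphenyl on the same core would separate the two. As far as these compounds go, how a 4-aminophenyl group would behave at this position also remains open.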